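The source may report more compounds than this note shows. Statements on the series, on what has been measured and on what is new or still open speak of the compounds shown alone.

Series notes. Compound 1 `O=C(O)CN1C(=O)/C(=C/c2nc3cc(F)ccc3n2Cc2ccccc2F)SC1=S` and compound 2 `O=C(O)CN1C(=O)/C(=C/c2nc3ccc(F)cc3n2Cc2ccccc2F)SC1=S` have the same atoms joined differently; the difference between the two cores is not broken down here. Compound 3 `COc1ccc2c(c1)nc(/C=C1\SC(=S)N(CC(=O)O)C1=O)n2Cc1ccccc1F` carries, relative to compound 1, methoxy in place of fluoro on an aromatic carbon. In a functional assay on HeLa cells (Homo sapiens) for cytotoxicity, read by MTT assay, with a stated time of 48 h (on this read-out higher numbers stand for weaker inhibition and lower numbers for stronger inhibition), compound 1 gives only a limit, > 50000 nM. In this assay compound 2 also gives only a limit, > 50000 nM. In this assay, among the compounds with values here, compound 3 gives 22500 nM, and the step of an at least 2.2-fold lower number from compound 1 to compound 3 (0.34 log units; beyond the scatter) is the only measured step in the set. Two of the three values sit at the limit (the limit of > 50000 nM in this assay, at which 2 of the 3 values shown sit), so the size of that step is bounded only from below. Compound 4 `COc1ccc2nc(/C=C3\SC(=S)N(CC(=O)O)C3=O)n(Cc3ccccc3F)c2c1` stands to compound 2 as compound 3 does to compound 1: the same change, methoxy in place of fluoro on an aromatic carbon, at a place described in the same words (methoxy in place of fluoro on an aromatic carbon). The same step is expected here, an at least 1.6-fold lower number from compound 2 to compound 4 (0.22 log units; that floor lies within the scatter), resting on the measured step of an at least 2.2-fold lower number from compound 1 to compound 3 (0.34 log units; beyond the scatter). Compound 4 is accordingly estimated at 30000 nM, between 10000 nM and 50000 nM in this assay, with a real chance that only a limit is reported.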

Compound 4, half-maximal inhibitory concentration: 28100 nM
Compound 4: the middle estimate sits 1.1-fold (0.03 log units) above what was measured; the range from low to high includes it.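

In this assay, methoxy in place of fluoro on an aromatic carbon on the second core gives an at least 1.7-fold lower number from compound 2 to compound 4 (0.25 log units; that floor lies within the scatter). Compound 2 gives only a limit, > 50000 nM, so this step is known only as a floor, and that floor does not by itself clear the scatter. The change therefore points the same way on the two cores shown, but this does not establish that it carries over with the same size: the same change on two cores in this assay, an at least 2.2-fold lower number (0.34 log units; beyond the scatter) from compound 1 to compound 3 and an at least 1.7-fold lower number (0.25 log units; that floor lies within the scatter) from compound 2 to compound 4; the limit leaves it open whether they differ

From the compounds shown here alone, the true size of each step stays open, as does the reading of other groups at these aromatic carbons, such as an amine, a hydroxyl or a longer ether chain like ethoxy. With so many values resting at one ceiling, the series has little room to separate fluoro-bearing compounds from one another, and the comparison between the two fluoro isomers cannot be read: the limit of > 50000 nM in this assay, at which 2 of the 4 values shown sit.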